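From Hydroxymethyl to 2-Hydroxyethyl: What to Expect

This account rests on a few compounds, and the source may have more. Where it says the series, first, only, none or still open, it means among the compounds named here.

In a toxicity assay on MT2 cells (Homo sapiens) for cytotoxicity, read by XTT assay, with a stated time of 4 days (a higher number here means that more compound is tolerated, a lower number that less compound is tolerated), compound 1 `Cc1nc([C@@H](NC(=O)c2ccc(-c3ccc(Cl)c(F)c3)[nH]2)[C@H]2CCCCN2)sc1CO` gives 17200 nM, compound 2 `Cc1nc([C@H](NC(=O)c2ccc(-c3ccc(Cl)c(F)c3)[nH]2)[C@H]2CCCCN2)sc1CO` gives 26000 nM, and compound 3 `Cc1ccc(-c2ccc(C(=O)N[C@@H](c3nc(C)c(CO)s3)[C@@H]3CCCCN3)[nH]2)cc1F` gives 28200 nM. Compound 3 therefore sits within the usual scatter of both other compounds, so the three values cannot be told apart.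

Compound 4 `Cc1ccc(-c2ccc(C(=O)N[C@@H](c3nc(C)c(CCO)s3)[C@@H]3CCCCN3)[nH]2)cc1F` differs from compound 3 by one small edit, hydroxymethyl in place of hydroxy on a saturated chain carbon bound to an aromatic carbon. In effect, hydroxymethyl becomes 2-hydroxyethyl.

Among the measured compounds shown here, no measured step alters this chain. The only one available is a 1.5-fold higher number from compound 1 to compound 2 (0.18 log units; within the scatter), and what it reflects is the fact that compounds 1 and 2 differ only in the configuration as drawn. It offers indirect guidance at best, showing only that these close relatives have so far stayed within the scatter of one another. No shift beyond the scatter is therefore expected in this assay, in either direction.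

The estimated step is a 1.1-fold lower number from compound 3 to compound 4 (0.04 log units; within the scatter). For compound 4, the expected value is 26000 nM, with an estimated range from 13000 nM to 52000 nM.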

Compound 4, half-maximal cytotoxic concentration: 21200 nM
The estimate for compound 4 lay 1.2-fold (0.09 log units) above the measured number; the range from low to high includes it.
By their numbers in this assay, from the lowest: compounds 1, 4, 2 and 3 (each within the scatter of the next).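

Among the compounds shown here, compound 4 is the only compound here whose chain differs, and in this assay going from hydroxymethyl to 2-hydroxyethyl gives a 1.3-fold lower number from compound 3 to compound 4 (0.12 log units; within the scatter). At this position, then, one added carbon with the hydroxy group kept leaves the tolerated concentration indistinguishable from that of compound 3, something the step between compounds of different configuration could only hint at. Nothing measured here speaks to the reason for this result.

This conclusion rests on a single pair, so it does not show how large a change the position can take. Going by these compounds, whether a longer chain such as 3-hydroxypropyl, or an amine or a carboxylic acid in place of the hydroxy group, would also stay within the scatter remains open.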